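The source may hold more compounds than are shown below. What is called first, only, known or untested is meant among the compounds shown, and "the series" means these compounds.

Among the three compounds whose numbers are known, compound 3 `N#Cc1ccccc1Cc1cnc(CCc2ccc(-c3ccccc3C(=O)O)cc2)[nH]1` stands second highest in an in vitro functional assay on cells for agonist activity at Bombesin receptor subtype-3 (Mus musculus), read by luminescence and calcium flux (on this read-out lower numbers stand for an effect already at smaller amounts and higher numbers for an effect only at larger amounts of compound), giving 642 nM. Its nearest neighbour is compound 2 `O=C(O)c1ccccc1-c1ccc(CCc2ncc(-c3ccccc3)[nH]2)cc1`, which gives 872 nM; the step of a 1.4-fold lower number from compound 2 to compound 3 (0.13 log units; within the scatter) lies within the scatter, so these two cannot be told apart. Far off stands compound 1 `O=C(O)c1ccccc1-c1ccc(CCc2ncc(Cc3cccc(Cl)c3)[nH]2)cc1`, which gives 31 nM; the step of a 21-fold higher number from compound 1 to compound 3 (1.32 log units; beyond the scatter) is large and beyond the scatter.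

Compound 4 `O=C(O)c1ccccc1-c1ccc(CCc2ncc(Cc3ccccc3Cl)[nH]2)cc1` differs from compound 3 in one place: chloro in place of cyano on an aromatic carbon. The change sits on an aromatic carbon of a six-membered aromatic ring of carbon only, ortho to a large group.

The step that bears on this change is a 21-fold higher number from compound 1 to compound 3 (1.32 log units; beyond the scatter), where 2-cyanophenyl replaced 3-chlorophenyl and the number rose sharply. Compound 4 reverses the swap of cyano for chloro while keeping the chloro at the 2-position rather than the 3-position, so only part of that step need be recovered. The step of a 1.4-fold lower number from compound 2 to compound 3 (0.13 log units; within the scatter) shows that the 2-cyanobenzyl group itself gave no gain over phenyl.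

Compound 4 is therefore expected to give a lower number than compound 3, a step of about a 4.3-fold lower number from compound 3 to compound 4 (0.63 log units; beyond the scatter) in this assay, estimated at 150 nM with a range from 40 nM to 500 nM.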

Compound 4, half-maximal effective concentration: 22 nM
For compound 4 the middle estimate is 6.8-fold (0.83 log units) above the measured one; the measured number lies below the stated range.
By their numbers in this assay, from the lowest: compounds 4 and 1 (each within the scatter of the next); then compounds 3 and 2 (each within the scatter of the next).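

At this aromatic carbon, ortho to a large group, the swap of cyano for chloro alone gives a 29-fold lower number from compound 3 to compound 4 (1.47 log units; beyond the scatter) in this assay, so a single small substituent on this six-membered aromatic ring of carbon only can change the number strongly. The step of a 1.4-fold lower number from compound 1 to compound 4 (0.15 log units; within the scatter) lies within the scatter, so 2-chlorophenyl and 3-chlorophenyl cannot be told apart here, and the large gap between compound 1 and compound 3 goes with the change from chloro to cyano rather than with the place of the substituent alone. Compound 3 had suggested that a substituted benzyl group offered no gain over phenyl, yet the step of a 40-fold lower number from compound 2 to compound 4 (1.60 log units; beyond the scatter) shows that with chloro as the substituent the same exchange has a large effect, so among these compounds the outcome depends on the substituent the benzyl group carries.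

Nothing given here explains why chloro and cyano differ so widely. Also open, as far as these compounds go, is where unsubstituted benzyl would fall, and how a fluoro, bromo or methoxy group at this same carbon would compare with chloro and cyano.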